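The compounds below may be only part of what the source reports. "The series", "measured", "known", "first", "only" and "open" are said of these compounds alone.

Working notes on the series. The shared core is the same throughout, and the aryl group on the five-membered aromatic ring with 3 nitrogen varies. Compound 1 `C=C1C[C@]23C[C@@]1(O)CC[C@H]2c1ccc(OS(=O)(=O)c2ccc(C)cc2)c(C)c1[C@@H]3Cn1cc(-c2ccc(C)cc2)nn1` and compound 2 `C=C1C[C@]23C[C@@]1(O)CC[C@H]2c1cc(Br)c(O)c(C)c1[C@@H]3Cn1cc(-c2ccc(Cl)cc2)nn1` carry further groups on the core; compound 3 `C=C1C[C@]23C[C@@]1(O)CC[C@@H]2c1cccc(C)c1[C@@H]3Cn1cc(-c2ccccc2)nn1` carries the plain core with phenyl on that ring. In a functional assay on SW480 cells (Homo sapiens) for cytotoxicity, read by MTT assay, with a stated time of 4 days (on this read-out lower numbers stand for stronger inhibition and higher numbers for weaker inhibition), compound 2 gives 18000 nM. For compound 1 this assay returns only a limit, > 20000 nM. For compound 3 this assay likewise returns only a limit, > 20000 nM. Compound 3 thus sits at the limit of > 20000 nM in this assay, at which 2 of the 3 values shown sit, and no number places it against compound 2. Among the compounds with values here, no two of the measured compounds differ in one place, so no measured step stands behind the change to compound 4 `C=C1C[C@]23C[C@@]1(O)CC[C@@H]2c1cccc(C)c1[C@@H]3Cn1cc(-c2ccccn2)nn1`. Compound 4 differs from compound 3 in one place: pyridin-2-yl in place of phenyl on an aromatic carbon. With nothing shown for this change in this assay, the expectation for compound 4 is no step beyond the scatter in either direction, and the most likely outcome is once more a limit rather than a number. Compound 4 is estimated at 20000 nM, with a range from 8000 nM to 50000 nM. The step this estimate means, a number no higher from compound 3 to compound 4 (the limit leaves the size open), is expected to stay within the scatter.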

Compound 4, half-maximal inhibitory concentration: > 20000 nM
Compound 4: a limit, no number; the forecaster's own chance of this, stated with the estimate: 60%; the middle value lies on the limit itself.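

In this assay compound 4 returns only a limit, > 20000 nM. Compound 3 also stands at a limit, and no step can be read between compound 3 and compound 4. The compounds shown leave open whether pyridin-2-yl in place of phenyl changes the value at all, in either direction.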